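This account rests on a few compounds, and the source may have more. Where it says the series, first, only, none or still open, it means among the compounds named here.

Measured so far in a functional assay on thoracic aorta for antagonist activity at thromboxane A2 receptor (Rattus norvegicus); on this read-out lower numbers stand for stronger inhibition and higher numbers for weaker inhibition: compound 1 `CC(C)c1ccc2c(CCCS(=O)(=O)Nc3ccccc3)cc(C(=O)O)c-2cc1` gives 12000 nM; compound 2 `CC(C)c1ccc2c(CCCS(=O)(=O)Nc3ccccc3)cc(S(=O)(=O)O)c-2cc1` gives 8700 nM; compound 3 `CC(C)c1ccc2c(CCCCS(=O)(=O)Nc3ccccc3)cc(S(=O)(=O)O)c-2cc1` gives 1500 nM.

Compound 2 stands second highest of the three numbers in this assay: compound 1 gives 12000 nM, a gap within the scatter, while compound 3 gives 1500 nM, the lowest number of the set and beyond the scatter from compound 2.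

Compound 4 `CC(C)c1ccc2c(CCCS(=O)(=O)Nc3ccc(Cl)cc3)cc(S(=O)(=O)O)c-2cc1` is compound 2 with chloro in place of hydrogen on an aromatic carbon, on an aromatic carbon of a six-membered aromatic ring of carbon only, para to a large group. Within the data shown here, no measured step touches this ring: the only single-point step, a 1.4-fold lower number from compound 1 to compound 2 (0.14 log units; within the scatter), alters the group on the core and lies within the scatter; compound 2 and compound 3 differ in the chain to the sulfonamide and give no guide to a change on the anilide. Among the measured compounds shown here, with no step bearing on it, compound 4 is expected to sit close to compound 2, the step of a 1.5-fold lower number from compound 2 to compound 4 (0.16 log units; within the scatter) expected to lie within the scatter, in no preferred direction. The estimate for compound 4 in this assay is 6000 nM, with a range from 2000 nM to 20000 nM.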

Compound 4, half-maximal inhibitory concentration: 860 nM
For compound 4 the middle estimate is 7.0-fold (0.84 log units) above the measured one; measured number outside the range, below it.
By their numbers in this assay, from the lowest: compounds 4 and 3 (each within the scatter of the next); then compounds 2 and 1 (each within the scatter of the next).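

In this assay, the ring of the anilide proves to be a responsive place in the series: phenyl to 4-chlorophenyl, on an aromatic carbon para to a large group, gives a 10-fold lower number from compound 2 to compound 4 (1.01 log units; beyond the scatter). The earlier single-point step (a 1.4-fold lower number from compound 1 to compound 2 (0.14 log units; within the scatter)) altered only the group on the core and so said nothing about this ring, where one added chlorine atom now clearly moves the number. No supporting measurement bears on why this step is so large.

As far as these compounds go, it remains open whether the shift is specific to chloro or also appears with fluoro, methyl or methoxy in the same place, and whether chloro elsewhere on this ring behaves alike. Also open, from the compounds shown here alone, is whether 4-chlorophenyl carries over to the longer chain of compound 3 or to the carboxylic acid of compound 1.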